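Swapping Trifluoromethyl for Fluoro in a Succinimide Amide

This account rests on a few compounds, and the source may have more. Where it says the series, first, only, none or still open, it means among the compounds named here.

Compound 1 `CCC(C(=O)N1CCN(c2ccccc2Cl)CC1)N1C(=O)CCC1=O` and compound 2 `CCC(C(=O)N1CCN(c2ccc(C(F)(F)F)cc2)CC1)N1C(=O)CCC1=O` were both tested in a functional assay on the whole organism (strain Swiss) with Mus musculus as the target, in the maximal electroshock model, with a stated time of 2 h, at a dose of 300 mg/kg by the intraperitoneal route; a higher number here means a stronger effect of the compound at the dose given, a lower number a weaker effect. In that test compound 1 gives 0%, and compound 2 gives 0%, so compound 2 stands level with compound 1, within the usual scatter. Compound 3 `CCC(C(=O)N1CCN(c2ccc(F)cc2)CC1)N1C(=O)CCC1=O` carries a single change from compound 2: fluoro in place of trifluoromethyl on an aromatic carbon. Since both measured compounds show no effect at this dose, the expected step is none beyond the scatter no change at the digits printed from compound 2 to compound 3 (within the scatter). Compound 3 is therefore estimated at 0%, with a range from 0% to 10%.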

Compound 3, a percentage reported as activity, at one dose (the size of the read-out at that dose, not a potency): 0%
Compound 3: middle estimate and measured number agree at the digits printed, within the range that was stated.
By their numbers in this assay, from the lowest: compounds 1, 2 and 3 (each within the scatter of the next).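

In this assay, fluoro in place of trifluoromethyl on this aromatic carbon gives no change at the digits printed from compound 2 to compound 3 (within the scatter), so a single fluorine here brings out no effect at this dose. The second change, 4-fluorophenyl in place of 2-chlorophenyl on the amine nitrogen in the ring, gives no change at the digits printed from compound 1 to compound 3 (within the scatter), and so also brings out no effect. No measured evidence is available to explain these results. From the compounds shown here alone, whether an amine or a nitrile on this aromatic carbon would give a read-out above zero remains open. So does whether a longer chain in place of the ethyl group on the shared core would do so.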